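The source may report more compounds than this note shows. Statements on the series, on what has been measured and on what is new or still open speak of the compounds shown alone.

Measured compounds:
- compound 1 `S=C(N/N=C/c1ccccc1)N1CCNCC1` gives 63000 nM
- compound 2 `C/C(=N\NC(=S)N1CCNCC1)c1cccc([N+](=O)[O-])c1` gives 62000 nM
- compound 3 `C/C(=N\NC(=S)N1CCNCC1)c1ccc(O)cc1` gives 60000 nM

All three numbers come from a functional assay on HL-60 cells (Homo sapiens) for antiproliferative activity, with a stated time of 48 h (on this read-out higher numbers stand for weaker inhibition and lower numbers for stronger inhibition), and all three sit in the same narrow band. Compound 1 carries the largest of the three numbers on paper, but its gaps to compound 2 and to compound 3 are both within the scatter, so no ordering among the three can be read from these data. Among the measured compounds shown here, the series so far shows no measurable response to the substituents tried on the aromatic ring.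

Compound 4 `S=C(N/N=C/c1ccc(Cl)cc1)N1CCNCC1` has not yet been tested. It differs from compound 1 by chloro in place of hydrogen on an aromatic carbon. For the measured compounds named here, no step between measured compounds bears directly on this change, so the expectation rests only on the flatness of the three numbers in hand.

Given that compound 1, compound 2 and compound 3 are indistinguishable within the scatter, the step from compound 1 to compound 4 is expected to be small, with no direction that can be called beyond the scatter; the expected step is a 1.1-fold lower number from compound 1 to compound 4 (0.06 log units; within the scatter). For compound 4 the estimate in this assay is 55000 nM, with an expected range from 20000 nM to 150000 nM.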

Compound 4, half-maximal inhibitory concentration: 69000 nM
Beside the measured number, compound 4's estimate is 1.3-fold (0.10 log units) below it; measured number inside the range.
By their numbers in this assay, from the lowest: compounds 3, 2, 1 and 4 (each within the scatter of the next).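

Among the compounds shown here, this is the first single-place step and the only direct reading of this position: in this assay chloro in place of hydrogen on an aromatic carbon, para to a large group, gives a 1.1-fold higher number from compound 1 to compound 4 (0.04 log units; within the scatter) and so leaves the number within the scatter. The position therefore accepts one chlorine atom without a readable shift, and hydrogen and chloro cannot be told apart here, so this change gives no handle on antiproliferative activity in these cells. No measured evidence bears on why the step is this small.

Still open, going by these compounds, is whether any other group in the same place, such as an amine, a carboxylic acid or a longer chain, would move the number beyond the scatter, since a single chloro step cannot speak for the position as a whole. Also open, on these data alone, is whether a change away from the aromatic ring, for example a carbonyl in place of the thiocarbonyl of the shared core, would give a readable step in this assay.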